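This account rests on a few compounds, and the source may have more. Where it says the series, first, only, none or still open, it means among the compounds named here.

Among the compounds with values here, compound 3 `Cc1nc(C)c([C@H](OC(C)(C)C)C(=O)O)c(N2CCC(C)(C)CC2)c1-c1ccc(OCCc2ccc(F)c(F)c2)cc1` is the one compound of the three for which an ADME assay on microsomes from liver (Rattus norvegicus) for metabolic stability, read by LC-MS, tested at 0.5 uM (a higher number here means that the compound lasts longer, a lower number that the compound disappears faster), gives a number: in this assay compound 3 gives 0.85 h. Compound 1 `COc1cccc(CCOc2ccc(-c3c(C)nc(C)c([C@H](OC(C)(C)C)C(=O)O)c3N3CCC(C)(C)CC3)cc2)c1` reaches only a limit of the assay, which in this assay reads > 2 h. Compound 2 `Cc1cc(CCOc2ccc(-c3c(C)nc(C)c([C@H](OC(C)(C)C)C(=O)O)c3N3CCC(C)(C)CC3)cc2)ccc1F` likewise stops at a limit, which in this assay reads > 2 h. Both therefore sit at the limit of > 2 h in this assay, at which 2 of the 3 values shown sit, and the step that the two limits leave unreadable from compound 1 to compound 2 cannot be read. Two steps do reach compound 3: an at least 2.3-fold lower number from compound 1 to compound 3 (0.37 log units; beyond the scatter) and an at least 2.3-fold lower number from compound 2 to compound 3 (0.37 log units; beyond the scatter), both of which end in the single number shown. Compound 4 `Cc1nc(C)c([C@H](OC(C)(C)C)C(=O)O)c(N2CCC(C)(C)CC2)c1-c1ccc(OCCc2cc(F)c(F)cc2F)cc1` differs from compound 3 by fluoro in place of hydrogen on an aromatic carbon, giving 2,4,5-trifluorophenyl where compound 3 carries 3,4-difluorophenyl. Within the data shown here, no measured step exchanges fluoro for hydrogen, so the two steps into compound 3 bear on it only loosely, and the step of a 1.2-fold higher number from compound 3 to compound 4 (0.07 log units; within the scatter) is expected to stay within the scatter. Compound 4 is thus estimated at 1 h in this assay, between 0.5 h and 2 h.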

Compound 4, half-life: > 2 h
Compound 4: only a limit was reported; the forecaster's own chance of this, stated with the estimate: 25%; at least 2.0-fold (0.30 log units) between middle value and limit.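

Fluoro in place of hydrogen on this aromatic carbon, ortho to a large group, is the first such exchange with a readable result, and in this assay it gives an at least 2.3-fold higher number from compound 3 to compound 4 (0.37 log units; beyond the scatter). Compound 4 gives > 2 h, which is a limit of the assay and not a number. The steps from compound 1 and from compound 2 to compound 4 cannot be read, and the 3,4-difluorophenyl of compound 3 is now the only ring shown with a number rather than a limit: the limit of > 2 h in this assay, at which 3 of the 4 values shown sit.

As far as these compounds go, how far compound 4 lies past its limit stays open, so the full size of the step is unknown. Also open, from the compounds shown here alone, is whether chloro or a nitrile on this same aromatic carbon would give a step like that of fluoro.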